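Adding a hydroxy group to compound 2

A few compounds are considered here, and "the series" means these few. Any claim that something is new, unique, unknown or untested is made for them only; others in the source may bear on it.

Measured in a functional assay on cells (Cancer cell lines, Homo sapiens) for inhibition, with a stated time of 48 h; a lower number here means a stronger inhibitor of growth, a higher number a weaker inhibitor of growth:
- compound 1 `COc1cc2c(/C=C3/C(=O)N(C)c4ccc(O)cc43)c(Cl)n(C)c2cc1C` gives 11800 nM
- compound 2 `COc1cc2c(/C=C3/C(=O)N(C)c4ccccc43)c[nH]c2cc1C` gives 60300 nM

Compound 2 stands highest of the two, beyond the scatter from compound 1. Compound 3 `COc1cc2c(/C=C3/C(=O)N(C)c4ccc(O)cc43)c[nH]c2cc1C` is compound 2 with hydroxy in place of hydrogen on an aromatic carbon. Among the measured compounds shown here, no measured step isolates this change. Compound 1 also carries the hydroxy, though it differs elsewhere too, and it gives 11800 nM. The expected step in this assay is therefore a moderate fall beyond the scatter, a 2.7-fold lower number from compound 2 to compound 3 (0.44 log units; beyond the scatter). For compound 3 the estimated value is 22000 nM, with an expected range of 8000 nM to 60000 nM.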

Compound 3, concentration for total growth inhibition: 31600 nM
For compound 3 the middle estimate is 1.4-fold (0.16 log units) below the measured one; measured number inside the range.
By their numbers in this assay, from the lowest: compound 1; then compounds 3 and 2 (each within the scatter of the next).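

In this assay, among the compounds shown here, hydroxy in place of hydrogen on an aromatic carbon, taken as the only change on the core of compound 2, gives a 1.9-fold lower number from compound 2 to compound 3 (0.28 log units; within the scatter). This first isolated reading at this position shows that the hydroxy alone leaves the number within the scatter, so compound 2 and compound 3 stand level. No measurement on hand bears on a cause for this result.

Open, going by these compounds, is whether an amine or a carboxylic acid on this same aromatic carbon would give a step beyond the scatter. Also open, on these data alone, is how the hydroxy reads on the other carbons of this ring.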